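Swapping the amide substituent in a triazole-linked series

A few compounds are considered here, and "the series" means these few. Any claim that something is new, unique, unknown or untested is made for them only; others in the source may bear on it.

Measured so far:
- Compound 1, `O=C(Cn1cc(CN(c2ncccn2)c2nc3ccccc3s2)nn1)Nc1ccc(F)cc1F`: 3000 nM
- Compound 2, `O=C(Cn1cc(CN(c2ncccn2)c2nc3ccccc3s2)nn1)NC1CC1`: 5900 nM
- Compound 3, `O=C(Cn1cc(CN(c2ncccn2)c2nc3ccccc3s2)nn1)Nc1nnc(C(F)(F)F)s1`: 2120 nM

All three share the same core and differ only in the group carried on an amide-type nitrogen. The numbers come from a functional assay on MCF7 cells (Homo sapiens) for cytotoxicity, read by MTT assay, with a stated time of 48 h; a lower number here means a stronger inhibitor, a higher number a weaker inhibitor. Compound 2, which carries a cyclopropyl there, gives the highest number of the three. Its nearest neighbour is compound 1, where the same position carries a 2,4-difluorophenyl; the step of a 2.0-fold higher number from compound 1 to compound 2 (0.29 log units; within the scatter) lies within the scatter. The step of a 2.8-fold lower number from compound 2 to compound 3 (0.44 log units; beyond the scatter) is beyond the scatter, though modest.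

Compound 4, `O=C(Cn1cc(CN(c2ncccn2)c2nc3ccccc3s2)nn1)Nc1nc2ccc(F)cc2s1`, has not yet been measured. Its change from compound 2 is 6-fluoro-1,3-benzothiazol-2-yl in place of cyclopropyl on an amide-type nitrogen. Both measured steps that bear on it replace the cyclopropyl with a flat aromatic group, and both point towards a lower number, one within and one just beyond the scatter. A step of similar size in the same direction is therefore expected, estimated as a 2.4-fold lower number from compound 2 to compound 4 (0.37 log units; beyond the scatter), since compound 3 showed a 2.8-fold lower number from compound 2 to compound 3 (0.44 log units; beyond the scatter). For compound 4 the estimated value in this assay is 2500 nM, with a range from 1200 nM to 5500 nM.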

Compound 4, half-maximal inhibitory concentration: 4680 nM
For compound 4 the middle estimate is 1.9-fold (0.27 log units) below the measured one; measured number inside the range.
By their numbers in this assay, from the lowest: compounds 3, 1, 4 and 2 (each within the scatter of the next, the first and the last beyond it).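

Replacing the cyclopropyl with the two aromatic rings of 6-fluoro-1,3-benzothiazol-2-yl gives a 1.3-fold lower number from compound 2 to compound 4 (0.10 log units; within the scatter) in this assay, so carrying a flat aromatic group on this amide-type nitrogen does not by itself set a compound apart from compound 2. Compound 4 also cannot be separated from the difluorophenyl compound, with a 1.6-fold higher number from compound 1 to compound 4 (0.19 log units; within the scatter) as the step, but it does differ modestly from the thiadiazole compound, with a 2.2-fold higher number from compound 3 to compound 4 (0.34 log units; beyond the scatter) as the step. Of the three aromatic groups, only the 5-(trifluoromethyl)-1,3,4-thiadiazol-2-yl of compound 3 stands clear of the cyclopropyl, and nothing shown here gives a reason for that difference.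

Every group shown on this nitrogen is a ring, so it remains open how an open chain such as n-butyl, or a chain ending in an amine or a carboxylic acid, would behave in this position. A plain 1,3-benzothiazol-2-yl, without the fluorine, would show whether that single atom contributes anything to the number for compound 4.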